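The compounds below may be only part of what the source reports. "The series", "measured", "known", "first", "only" and "open" are said of these compounds alone.

Of the compounds shown here, three sharing one core have been measured in an ADME assay for permeability, using PAMPA, at pH 7.4; on this read-out higher numbers stand for higher permeability and lower numbers for lower permeability. Compound 1 `Cc1cc(NC(=O)Nc2ccc(O)cc2)c2ccccc2n1` gives 3 10^-6 cm/s, compound 2 `Cc1cc(NC(=O)Nc2cccnc2)c2ccccc2n1` gives 63 10^-6 cm/s, and compound 3 `Cc1cc(NC(=O)Nc2ccc(Cl)cc2)c2ccccc2n1` gives 537 10^-6 cm/s, the highest number of the three. Compound 4 `Cc1cc(NC(=O)Nc2cccc(Cl)c2)c2ccccc2n1` has the same atoms as compound 3, joined differently: 3-chlorophenyl in place of 4-chlorophenyl on an amide-type nitrogen. In plain terms, 3-chlorophenyl stands in place of 4-chlorophenyl on an amide-type nitrogen whose other neighbour is the carbonyl carbon.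

The measured steps all replace one group with a different one, and all lie beyond the scatter. Two are large, a 21-fold higher number from compound 1 to compound 2 (1.32 log units; beyond the scatter) and a 180-fold higher number from compound 1 to compound 3 (2.25 log units; beyond the scatter), while an 8.5-fold higher number from compound 2 to compound 3 (0.93 log units; beyond the scatter) is modest. For the measured compounds named here, none of them keeps the chloro group and only shifts it, so the data offer no direct precedent for this change. Going by the values given here, they show only that swapping groups can move the number a long way. With the atoms unchanged, a much smaller step than any of these is expected, most likely none beyond the scatter in this assay. The expected step is a 1.2-fold lower number from compound 3 to compound 4 (0.08 log units; within the scatter). For compound 4 the estimated value is 450 10^-6 cm/s, with an expected range of 180 10^-6 cm/s to 1000 10^-6 cm/s.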

Compound 4, apparent permeability: 566 10^-6 cm/s
Estimate against measurement, compound 4: 1.3-fold (0.10 log units) below; low and high end bracket the measured number.
By their numbers in this assay, from the lowest: compound 1; then compound 2; then compounds 3 and 4 (each within the scatter of the next).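

In this assay, shifting the chloro group so that 3-chlorophenyl stands in place of 4-chlorophenyl on the amide-type nitrogen leaves the read-out unchanged within the scatter (a 1.1-fold higher number from compound 3 to compound 4 (0.02 log units; within the scatter)). For the compounds shown here, the earlier compounds showed only that replacing one group with a different one could move the number a long way, whereas this pair shows a case in which the same atoms, joined differently, produce no step that can be told from repeat-measurement noise. Compound 4 also stands well clear of the two compounds without chlorine, with a modest step from pyridin-3-yl (a 9.0-fold higher number from compound 2 to compound 4 (0.95 log units; beyond the scatter)) and a large one from 4-hydroxyphenyl (a 190-fold higher number from compound 1 to compound 4 (2.28 log units; beyond the scatter)), so both chlorophenyl compounds keep their place at the top of this small set, neither one ahead of the other.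

No measurement shown here bears on why the two chlorophenyl compounds read alike.

Going by these compounds alone, it remains open whether another group on this ring, such as an amine or a carboxylic acid, would also show no step when shifted in the same way. As far as these compounds go, it is equally open whether the chloro shift would stay this quiet on a core carrying a longer chain in place of the methyl group.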